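The compounds below may be only part of what the source reports. "The series", "measured", "known", "first", "only" and "open" are said of these compounds alone.

Measured so far:
- compound 1, `CCCC[C@H](NC(=O)[C@H](CCCCN)NC(=O)[C@H](CCCNC(=N)N)NC(=O)c1ccc(/C=C/C(N)=O)cc1)C(N)=O` — "impermeable" (no number reported)
- compound 2, `CCCC[C@H](NC(=O)[C@H](CCCCN)NC(=O)[C@H](CCCNC(=N)N)NC(=O)c1ccc(/C=C2\SC(=O)N(C3CCCCC3)C2=O)cc1)C(N)=O` — 1.69 10^-6 cm/s
- compound 3, `CCCC[C@H](NC(=O)[C@H](CCCCN)NC(=O)[C@H](CCCNC(=N)N)NC(=O)c1ccc(/C=C2\NC(=S)N(c3ccccc3)C2=O)cc1)C(N)=O` — "impermeable" (no number reported)

Of the compounds shown here, three sharing one core have been tested in an ADME assay for permeability, using PAMPA; on this read-out lower numbers stand for lower permeability and higher numbers for higher permeability. Compound 1 gives no number in this assay and is reported only as "impermeable" (no number reported). Compound 3 is likewise reported only as "impermeable" (no number reported). Only compound 2 gives a figure, 1.69 10^-6 cm/s, so compound 1 stands among the two compounds for which no value could be read at all.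

Compound 4, `CCCC[C@H](NC(=O)[C@H](CCCCN)NC(=O)[C@H](CCCNC(=N)N)NC(=O)c1ccc(/C=C2\SC(=S)N(CCCC)C2=O)cc1)C(N)=O`, has not yet been measured. It differs from compound 1 in one place: a group of 12 heavy atoms (8 carbon, 1 nitrogen, 1 oxygen, 2 sulfur; one five-membered non-aromatic ring with 2 hetero atoms) in place of a group of 5 heavy atoms (3 carbon, 1 nitrogen, 1 oxygen; no ring), on an aromatic carbon. For the measured compounds named here, no measured pair shows this step, so its size can only be guessed. Compound 2, which also carries a five-membered non-aromatic ring at that aromatic carbon, gives 1.69 10^-6 cm/s, and compound 4 resembles it more closely than it resembles compound 3. The expectation is therefore that compound 4 moves from the unreadable state of compound 1 to a measurable reading, roughly in the region of compound 2, though a repeat of an unreadable result cannot be ruled out. Compound 4 is estimated to give 1.5 10^-6 cm/s in this assay, within a range of 0.4 10^-6 cm/s to 4.5 10^-6 cm/s.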

Compound 4, apparent permeability: 1.61 10^-6 cm/s
Beside the measured number, compound 4's estimate is 1.1-fold (0.03 log units) below it; measured number inside the range.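

In this assay, for the compounds shown here, compound 1 gives "impermeable" (no number reported) and compound 4 gives 1.61 10^-6 cm/s — with only one number in the pair, no step from compound 1 to compound 4 can be read. The compounds shown leave open which feature of the group on that aromatic carbon separates a numerical reading from none. Nothing available explains this result.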